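Naphthalen-2-yl in Place of 4-Chlorophenyl on Sulfur

The compounds below may be only part of what the source reports. "The series", "measured", "known", "first", "only" and "open" are said of these compounds alone.

Compound 1, `OB1OCc2ccc(-n3ccc4ccccc43)cc21`, in an ADME assay on L929 cells (Mus musculus) for cytotoxicity, read by resazurin assay, with a stated time of 72 h; a lower number here means a stronger inhibitor, a higher number a weaker inhibitor: > 10 ug/mL, a limit of the assay.
Compound 2, `OB1OCc2ccc(-n3cc(Sc4ccc(Cl)cc4)c4ccccc43)cc21`, in this assay: > 10 ug/mL, a limit of the assay.
Compound 3, `OB1OCc2ccc(-n3cc(Sc4ccc(F)cc4)c4ccccc43)cc21`, in this assay: > 10 ug/mL, a limit of the assay.

Compound 2 stands at the limit of > 10 ug/mL in this assay, at which 3 of the 3 values shown sit. Compound 4, `OB1OCc2ccc(-n3cc(Sc4ccc5ccccc5c4)c4ccccc43)cc21`, differs from compound 2 by naphthalen-2-yl in place of 4-chlorophenyl on a sulfur. The measured steps that bear on this change are a step that the two limits leave unreadable from compound 1 to compound 2, a step that the two limits leave unreadable from compound 1 to compound 3 and a step that the two limits leave unreadable from compound 2 to compound 3; none of them has a readable size, so no direction can be set for this assay beyond the scatter. Compound 4 is therefore expected to show a step that the limit leaves unreadable from compound 2 to compound 4. The estimate for compound 4 is 15 ug/mL, expected to lie between 5 ug/mL and 45 ug/mL.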

Compound 4, half-maximal inhibitory concentration: > 10 ug/mL
Compound 4 gave a limit, no number (the forecaster's own chance of this, stated with the estimate: 75%); the middle value is on the limit's open side.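

In this assay, among these compounds, compound 4 gives only a limit, as do compound 2 and compound 3, so no step from either of them to compound 4 can be read. From the compounds shown here alone, the actual cytotoxic potency of all these compounds remains open.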